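A few compounds are considered here, and "the series" means these few. Any claim that something is new, unique, unknown or untested is made for them only; others in the source may bear on it.

In a functional assay on MCF7 cells (Homo sapiens) for inhibition, read by MTT assay, with a stated time of 48 h (a higher number here means a weaker inhibitor, a lower number a stronger inhibitor), three compounds with a shared core have been measured: compound 1 `O=C(C=CNc1cc(-c2ccccc2)nn1-c1ccccc1)c1ccc(Br)cc1` gives 21700 nM, compound 2 `O=C(C=CNc1cc(-c2ccccc2)nn1-c1ccccc1)c1ccc(Cl)cc1` gives 8070 nM and compound 3 `Cc1ccc(C(=O)C=CNc2cc(-c3ccccc3)nn2-c2ccccc2)cc1` gives 30200 nM. Compound 3 therefore belongs to the upper pair of numbers, as the measurements show a 1.4-fold higher number from compound 1 to compound 3 (0.14 log units; within the scatter) and a 3.7-fold higher number from compound 2 to compound 3 (0.57 log units; beyond the scatter). Compound 4 `O=C(C=CNc1cc(-c2ccccc2)nn1-c1ccccc1)c1ccc(F)cc1` makes one change to compound 3: fluoro in place of methyl on an aromatic carbon. Going by the values given here, no measured step makes this exact swap, so the closest guides are the other halogen comparisons above, along with a 2.7-fold lower number from compound 1 to compound 2 (0.43 log units; beyond the scatter). They differ in size, so the expectation is uncertain. Expected in this assay is a 2.0-fold lower number from compound 3 to compound 4 (0.30 log units; within the scatter). For compound 4, the estimated value is 15000 nM, with an expected range of 6000 nM to 32000 nM.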

Compound 4, half-maximal inhibitory concentration: 9180 nM
For compound 4 the middle estimate is 1.6-fold (0.21 log units) above the measured one; measured number inside the range.
By their numbers in this assay, from the lowest: compounds 2 and 4 (each within the scatter of the next); then compounds 1 and 3 (each within the scatter of the next).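

In this assay, fluoro in place of methyl (a 3.3-fold lower number from compound 3 to compound 4 (0.52 log units; beyond the scatter)) and fluoro in place of bromo (a 2.4-fold lower number from compound 1 to compound 4 (0.37 log units; beyond the scatter)) both lower the number, while fluoro in place of chloro (a 1.1-fold higher number from compound 2 to compound 4 (0.06 log units; within the scatter)) leaves the two compounds indistinguishable. At this ring position, then, the halogens do not behave as one set: fluoro groups with chloro, while bromo groups with methyl. Nothing measured here explains this split. Still open, on these data alone, is how an amine, a methoxy group or a carboxylic acid would fare at this position.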